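This account rests on a few compounds, and the source may have more. Where it says the series, first, only, none or still open, it means among the compounds named here.

The three measured compounds share one core carrying an aryl group on a ring nitrogen. Compound 1 `O=C1C2=C(C(=O)c3ncccc31)C1(CS2)NC(=O)N(c2ccc([N+](=O)[O-])cc2)C1=O` bears a nitro group on that aryl ring, and in a functional assay on CCRF-CEM cells (Homo sapiens) for antiproliferative activity, read by MTT assay, with a stated time of 96 h (on this read-out lower numbers stand for stronger inhibition and higher numbers for weaker inhibition), compound 1 gives 1 nM. Compound 2 `CCN(CC)c1ccc(N2C(=O)NC3(CSC4=C3C(=O)c3ncccc3C4=O)C2=O)cc1` bears diethylamino instead, and in this assay compound 2 gives 20 nM. Compound 3 `O=C1NN(c2ccc(Cl)cc2)C(=O)C2(CSC3=C2C(=O)c2ncccc2C3=O)N1`, built on a somewhat different core with a chloro substituent, gives 50 nM in this assay. Among these three numbers compound 2 stands second highest: compound 3 shows a higher number, while the step of a 20-fold higher number from compound 1 to compound 2 (1.30 log units; beyond the scatter) separates compound 2 from compound 1.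

Compound 4 `CC(C)(C)c1ccc(N2C(=O)NC3(CSC4=C3C(=O)c3ncccc3C4=O)C2=O)cc1` differs from compound 2 in one place: tert-butyl in place of diethylamino on an aromatic carbon. Within the data shown here, the only measured step that bears on this position on the same core is a 20-fold higher number from compound 1 to compound 2 (1.30 log units; beyond the scatter), which shows that exchanging the substituent here can move the number by a large amount. Among the measured compounds shown here, no measured compound carries tert-butyl, so neither the direction nor the size of the new step is anchored by a close precedent. Compound 4 is therefore expected to land near compound 2, with the step of a 1.3-fold higher number from compound 2 to compound 4 (0.10 log units; within the scatter) expected to stay within or close to the scatter, while the wide range reflects the large swing seen in a 20-fold higher number from compound 1 to compound 2 (1.30 log units; beyond the scatter). Compound 4 is estimated at 25 nM, between 6 nM and 100 nM.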

Compound 4, half-maximal inhibitory concentration: 200 nM
Estimate against measurement, compound 4: 8.0-fold (0.90 log units) below, and the stated range ends below it.
By their numbers in this assay, from the lowest: compound 1; then compound 2; then compound 3; then compound 4.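

In this assay, among these compounds, the exchange of diethylamino for tert-butyl on this aromatic carbon, para to a large group, is not a quiet one: a 10-fold higher number from compound 2 to compound 4 (1.00 log units; beyond the scatter) shows that this position responds strongly even when the leaving and entering groups both lack a ring and a net charge, so the earlier step involving nitro was not the only sizeable change here. With a 200-fold higher number from compound 1 to compound 4 (2.30 log units; beyond the scatter) the three groups on the shared core now span a wide range, with nitro giving the lowest number, diethylamino an intermediate one and tert-butyl the highest, and this order holds only for these compounds. No measurement available here explains why tert-butyl gives so much weaker inhibition than diethylamino.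

The compounds shown leave open where methoxy, a plain amine or a carboxylic acid would fall at this position on the shared core. They also leave open whether the nitrogen of diethylamino matters in itself, a question that isopropyl or dimethylamino on the same aromatic carbon could help to separate.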